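Amide aryl variation: compound 3 awaits measurement

The source may hold more compounds than are shown below. What is called first, only, known or untested is meant among the compounds shown, and "the series" means these compounds.

Measured so far:
compound 1 `O=C(COc1ccc2cc(/C=C3/SC(=O)NC3=O)ccc2c1)Nc1cccc(C(F)(F)F)c1` — in an assay on isolated protein for inhibition of histone deacetylase 8 (Homo sapiens), with a stated time of 1 h (a higher number here means a weaker inhibitor, a lower number a stronger inhibitor), compound 1 gives > 50000 nM
compound 2 `Cc1cc(NC(=O)COc2ccc3cc(/C=C4/SC(=O)NC4=O)ccc3c2)no1` — in this assay compound 2 gives > 50000 nM

The value for compound 1 is a limit of the assay, not a number. The value for compound 2 is likewise a limit. The step that the two limits leave unreadable from compound 1 to compound 2 therefore has no readable size, as both values sit at the limit of > 50000 nM in this assay, at which 2 of the 2 values shown sit. Among the measured compounds shown here, compound 2 thus stands at the assay limit, and the one other value shown is also a limit; nothing ranks the two.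

Compound 3 is `O=C(COc1ccc2cc(/C=C3/SC(=O)NC3=O)ccc2c1)Nc1cccc(Cl)c1`. It differs from compound 2 by 3-chlorophenyl in place of 5-methyl-1,2-oxazol-3-yl on an amide-type nitrogen. For the measured compounds named here, the only measured step that bears on this position is the one from compound 1 to compound 2, and it is unreadable, so no direction can be drawn from it. Compound 3 is expected to give 60000 nM, within 20000 nM to 200000 nM, most likely again reported only as a limit. The expected step that the limit leaves unreadable from compound 2 to compound 3 is thus estimated as none beyond the scatter.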

Compound 3, half-maximal inhibitory concentration: > 50000 nM
Compound 3 was reported as a limit; the forecaster's own chance of this, stated with the estimate: 85%; the middle value lies beyond the limit too.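

In this assay compound 3 gives > 50000 nM, a limit of the assay and not a number. Neither step to compound 3, from compound 1 or from compound 2, can be read: the limit of > 50000 nM in this assay, at which 3 of the 3 values shown sit. The compounds shown leave open how these amide groups rank against one another.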